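A few compounds are considered here, and "the series" means these few. Any claim that something is new, unique, unknown or untested is made for them only; others in the source may bear on it.

Measured so far:
- Compound 1 `CN(C)c1ccc(CNC(=O)Nc2cccc3cnccc23)cc1`: 157 nM
- Compound 2 `O=C(NCc1ccc(N2CCCCCC2)cc1)Nc1cccc2cnccc12`: 3.3 nM

Compound 2 holds the lowest of the two numbers measured in a functional assay for antagonist activity at transient receptor potential cation channel subfamily V member 1 (Homo sapiens), read by calcium flux; a higher number here means a weaker inhibitor, a lower number a stronger inhibitor. Its nearest neighbour is compound 1, which gives 157 nM in this assay, a gap described as beyond the scatter. Compound 3 `O=C(NCc1ccc(N2CCCCCCC2)cc1)Nc1cccc2cnccc12` is not yet measured. It differs from compound 2 in one place: a group of 8 heavy atoms (7 carbon, 1 nitrogen; one eight-membered non-aromatic ring with 1 hetero atom) in place of a group of 7 heavy atoms (6 carbon, 1 nitrogen; one seven-membered non-aromatic ring with 1 hetero atom), on an aromatic carbon. Within the data shown here, only one measured step bears on this position: a 48-fold lower number from compound 1 to compound 2 (1.68 log units; beyond the scatter), where the enlarged cyclic amine in place of the dimethylamino group produced a large gain in potency. That step concerns a different change, an open group replaced by a seven-membered ring, and nothing measured shows what a further widening of that ring does. Among the measured compounds shown here, the single step therefore offers no firm direction for a ring expanded by one carbon. Compound 3 is estimated to land close to compound 2, with a step of a 1.5-fold higher number from compound 2 to compound 3 (0.18 log units; within the scatter), which is within the scatter. The expected value for compound 3 is 5 nM, with a range from 1.5 nM to 20 nM.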

Compound 3, half-maximal inhibitory concentration: 4.7 nM
Compound 3: the middle estimate sits 1.1-fold (0.03 log units) above what was measured; low and high end bracket the measured number.
By their numbers in this assay, from the lowest: compounds 2 and 3 (each within the scatter of the next); then compound 1.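

In this assay the eight-membered ring in place of azepan-1-yl gives a 1.4-fold higher number from compound 2 to compound 3 (0.15 log units; within the scatter) and so the two ring sizes cannot be told apart at this position, on an aromatic carbon para to a large group. The large gain over the dimethylamino group is therefore not confined to the seven-membered ring: the eight-membered ring also gives a 33-fold lower number from compound 1 to compound 3 (1.52 log units; beyond the scatter) and this places both cyclic amines shown well clear of the open group. Nothing available here explains why one added ring carbon leaves the number within the scatter, or why both rings stand so far from the dimethylamino group.

The compounds shown leave open how smaller rings such as pyrrolidine or piperidine would behave at this position, and whether a ring carrying a second hetero atom, such as morpholine, would keep the number of the two larger rings. They also leave open whether ring closure itself matters, since an open amine with longer chains, such as dipropylamino, would be needed to separate the presence of a ring from the number of carbons.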